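Trimming the alkyl chain on a squaramide-type scaffold

A few compounds are considered here, and "the series" means these few. Any claim that something is new, unique, unknown or untested is made for them only; others in the source may bear on it.

Measured so far:
compound 1, `CCc1cc(C#N)ccc1C/N=c1\c(O)c(O)\c1=N/C(C)(C)C`, 240 nM
compound 2, `CCC(C)(C)/N=c1\c(O)c(O)\c1=N/Cc1ccc(C#N)cc1Cl`, 130 nM
compound 3, `CCC(C)(C)/N=c1\c(O)c(O)\c1=N/Cc1ccc(C#N)cc1`, 1100 nM

In a functional assay for inhibition, with Rattus norvegicus as the target (a higher number here means a weaker inhibitor, a lower number a stronger inhibitor), compound 3 gives the highest of the three numbers, so it is the weakest inhibitor shown; compound 1 sits nearer to it, compound 2 furthest. Within the data shown here, the only single-point step measured is an 8.5-fold higher number from compound 2 to compound 3 (0.93 log units; beyond the scatter), and it concerns the aromatic ring, not the alkyl chain.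

Compound 4, `CC(C)(C)/N=c1\c(O)c(O)\c1=N/Cc1ccc(C#N)cc1`, differs from compound 3 by hydrogen in place of methyl on a saturated chain carbon, two bonds along the chain from a double-bonded nitrogen. Among the measured compounds shown here, no measured pair isolates this change: compound 1 also carries tert-butyl, but it differs from compound 3 at the ring as well, so its value speaks to two changes at once and cannot be separated. For the measured compounds named here, with no direct precedent, a small step is expected, most likely within the usual scatter and in no certain direction; the removal of one carbon from the chain is a modest edit next to the ring change already seen.

Compound 4 is therefore estimated at 1300 nM in this assay, with a range from 450 nM to 3800 nM, which corresponds to an expected step of a 1.2-fold higher number from compound 3 to compound 4 (0.07 log units; within the scatter).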

Compound 4, half-maximal inhibitory concentration: 270 nM
Estimate against measurement, compound 4: 4.8-fold (0.68 log units) above; measured number below the stated range.
By their numbers in this assay, from the lowest: compounds 2, 1 and 4 (each within the scatter of the next, the first and the last beyond it); then compound 3.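

In this assay, trimming 1,1-dimethylpropyl to tert-butyl, which puts hydrogen in place of methyl on a saturated chain carbon, gives a 4.1-fold lower number from compound 3 to compound 4 (0.61 log units; beyond the scatter) and so shows that this single chain carbon matters: of this pair, the tert-butyl compound is the stronger inhibitor. Among these compounds, the step of a 1.1-fold higher number from compound 1 to compound 4 (0.05 log units; within the scatter) is the first clean reading of the ring with tert-butyl held constant, and because it lies within the scatter, ethyl and hydrogen on that aromatic carbon cannot be told apart with this chain in place. No measurement at hand bears on why removing one chain carbon shifts the number while this ring change does not.

The compounds shown leave open whether the trend continues with still smaller or differently shaped chain groups, such as isopropyl or cyclopropyl, in place of tert-butyl. Among the compounds shown here, they also leave open whether chloro on the ring, which gave the one earlier measured ring step with 1,1-dimethylpropyl, would change the number when paired with tert-butyl, and how a methoxy group there would compare.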